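Hydroxymethyl to carboxy in a flat series

The source may hold more compounds than are shown below. What is called first, only, known or untested is meant among the compounds shown, and "the series" means these compounds.

Of the compounds shown here, three have been read so far in a functional assay on MIA PaCa-2 cells (Homo sapiens) for inhibition, read by MTT assay, with a stated time of 48 h, tested at 10 uM; on this read-out higher numbers stand for more inhibition of growth at the one concentration tested and lower numbers for less inhibition of growth. Compound 1 (`Cc1cc(=O)c2c(O)cc(OCc3ccccc3)c([C@H]3CCN(C)C[C@H]3O)c2o1`) gives 14%, compound 2 (`Cc1cc(=O)c2c(O)cc(O)c([C@H]3CCN(C)C[C@H]3OC(=O)c3ccco3)c2o1`) gives 13%, and compound 3 (`Cc1cc(=O)c2c(O)c(CN3CCCC3CO)c(O)c([C@H]3CCN(C)C[C@H]3O)c2o1`) gives 13%. Compound 3 is level with compound 2 and within the scatter of compound 1, so these readings do not separate the three compounds.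

Compound 4 (`Cc1cc(=O)c2c(O)c(CN3CCCC3C(=O)O)c(O)c([C@H]3CCN(C)C[C@H]3O)c2o1`) has carboxy in place of hydroxymethyl on a saturated ring carbon, next to the ring nitrogen: carboxy in place of hydroxymethyl on a saturated ring carbon. The side chain thus changes from 2-(hydroxymethyl)pyrrolidin-1-yl to 2-carboxypyrrolidin-1-yl.

Within the data shown here, no measured pair shows the effect of this change, so the expectation rests on the value of its closest neighbour, compound 3 at 13%. No shift beyond the scatter is expected in this assay. The expected change is a number 2 percentage points lower from compound 3 to compound 4 (within the scatter), which stays within the scatter. Compound 4 is estimated at 11%, with an expected range of 2% to 23%.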

Compound 4, percent growth inhibition at one concentration: 10%
Compound 4: the middle estimate sits 1 percentage points above what was measured; the measured number falls inside the stated range.
By their numbers in this assay, from the lowest: compounds 4, 2, 3 and 1 (each within the scatter of the next).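

Carboxy in place of hydroxymethyl on a saturated ring carbon, next to the ring nitrogen, gives in this assay a first reading of a change in one place: a number 3 percentage points lower from compound 3 to compound 4 (within the scatter). At this position on the (2-(hydroxymethyl)pyrrolidin-1-yl)methyl side chain, the exchange therefore produces no shift that can be told from the scatter at the one concentration tested. Nothing available explains this result or bears on it.

On these data alone, whether a methyl ester or a primary amide on the same ring carbon, or a longer chain such as 2-hydroxyethyl, would move the reading remains open. The compounds shown also leave open whether this position matters at all, as only this one exchange can be read there.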